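From 4-ethylphenyl to 3-bromophenyl on a sulfonamide nitrogen

The source may hold more compounds than are shown below. What is called first, only, known or untested is meant among the compounds shown, and "the series" means these compounds.

Measured so far in a functional assay on MCF7 cells (Homo sapiens) for antiproliferative activity, read by sulforhodamine B assay, with a stated time of 48 h; a lower number here means a stronger inhibitor, a higher number a weaker inhibitor:
compound 1 `O=C1NCCN1c1ccc(S(=O)(=O)Nc2ccc(I)cc2)cc1` – 600 nM
compound 2 `CCc1ccc(NS(=O)(=O)c2ccc(N3CCNC3=O)cc2)cc1` – 810 nM

For the measured compounds named here, compound 2 at 810 nM stands within the usual scatter of compound 1 , the only other measured compound. Going by the values given here, compound 3 `O=C1NCCN1c1ccc(S(=O)(=O)Nc2cccc(Br)c2)cc1` has 3-bromophenyl in place of 4-ethylphenyl on a sulfonamide nitrogen as its one change. Among the compounds with values here, only one measured step bears on this: a 1.4-fold higher number from compound 1 to compound 2 (0.13 log units; within the scatter) with ethyl in place of iodo on an aromatic carbon. Within the data shown here, no measured compound carries 3-bromophenyl, so the range stays wide. In this assay the expected 1.1-fold lower number from compound 2 to compound 3 (0.03 log units; within the scatter) does not go beyond the scatter, and no direction is expected. Compound 3 is estimated at 750 nM with an expected range from 250 nM to 2300 nM.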

Compound 3, half-maximal inhibitory concentration: 100 nM
Compound 3: the middle estimate sits 7.5-fold (0.88 log units) above what was measured; the measured number lies below the stated range.
By their numbers in this assay, from the lowest: compound 3; then compounds 1 and 2 (each within the scatter of the next).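

The switch to 3-bromophenyl on a sulfonamide nitrogen gives an 8.1-fold lower number from compound 2 to compound 3 (0.91 log units; beyond the scatter) and a 6.0-fold lower number from compound 1 to compound 3 (0.78 log units; beyond the scatter) in this assay, so changes at this position can move the number beyond the scatter. The 4-ethylphenyl and 4-iodophenyl compounds had not shown this, as they lie within the scatter of each other. Nothing available here explains the difference.

The halogen and its place on the phenyl ring change together in these steps, and 4-bromophenyl would help to separate the two. Going by these compounds, how a phenyl ring carrying an amine or a carboxylic acid would behave also remains open.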